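From 4-fluorobenzyl to 3-fluorobenzyl on compound 1

The compounds below may be only part of what the source reports. "The series", "measured", "known", "first", "only" and "open" are said of these compounds alone.

In a physicochemical assay for solubility, using the shake flask method, in simulated intestinal fluid, measured as kinetic solubility, with a stated time of 2 h, at 25 degrees C, at pH 6.5 (on this read-out higher numbers stand for higher solubility and lower numbers for lower solubility), compound 1 `Cc1noc(-c2nc(C)c3c(c2N)C(=O)N(Cc2ccc(F)cc2)C3=O)n1` gives < 5000 nM, which is a limit. Compound 3 `Cc1noc(-c2nc(C)c3c(c2N)C(=O)N(Cc2ccc(OC(F)(F)F)cc2)C3=O)n1` gives < 5000 nM, also a limit. For the measured compounds named here, compound 2 `Cc1noc(-c2nc(C)c3c(c2N)C(=O)N(Cc2ccc(Oc4ccc(F)cc4)cc2)C3=O)n1` gives 23800 nM, the only full number so far. The evidence on where compound 1 stands is therefore (the limit of < 5000 nM in this assay, at which 2 of the 3 values shown sit).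

Compound 4 `Cc1noc(-c2nc(C)c3c(c2N)C(=O)N(Cc2cccc(F)c2)C3=O)n1` departs from compound 1 through (3-fluorophenyl in place of 4-fluorophenyl on a saturated chain carbon bound to an amide-type nitrogen in a ring). The same atoms are joined differently, with 3-fluorophenyl in place of 4-fluorophenyl on a saturated chain carbon bound to an amide-type nitrogen in a ring.

Going by the values given here, no measured step moves the fluoro group, so the evidence is indirect. The steps replace that group instead: an at least 4.7-fold higher number from compound 1 to compound 2 (0.67 log units; beyond the scatter) with 4-fluorophenoxy entering, a step that the two limits leave unreadable from compound 1 to compound 3 with trifluoromethoxy entering, and an at least 4.7-fold lower number from compound 2 to compound 3 (0.67 log units; beyond the scatter) on the return. Neither 4-fluorophenoxy nor trifluoromethoxy enters in compound 4, so no step beyond the scatter is expected in this assay. The estimated step is a step that the limit leaves unreadable from compound 1 to compound 4. A report as a limit is also expected to be likely. For compound 4 the estimated value is 3500 nM, with an expected range from 1200 nM to 9000 nM.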

Compound 4, solubility: < 5000 nM
Compound 4 was reported as a limit; the forecaster's own chance of this, stated with the estimate: 70%; the middle value lies beyond the limit too.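

In this assay compound 4 gives < 5000 nM, which is a limit. For the compounds shown here, compound 1 is also reported as a limit, and no step between compound 1 and compound 4 can be read. Still open, as far as these compounds go, is whether 3-fluorophenyl and 4-fluorophenyl differ at all in this assay, with neither compound carrying a full number.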